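The source may report more compounds than this note shows. Statements on the series, on what has been measured and on what is new or still open speak of the compounds shown alone.

Compound 1 `N#Cc1ccc(C(=O)/C=C/c2ccncc2)cc1`: 123000 nM
Compound 2 `O=C(/C=C/c1ccncc1)c1ccccc1`: 49000 nM

In a functional assay with Rattus norvegicus as the target (on this read-out higher numbers stand for weaker inhibition and lower numbers for stronger inhibition), compound 2 holds the lowest of the two numbers shown, with compound 1 the nearest at a higher number. Compound 3 `CN(C)c1ccc(C(=O)/C=C/c2ccncc2)cc1` differs from compound 2 by dimethylamino in place of hydrogen on an aromatic carbon. Among the measured compounds shown here, the only measured step that bears on this change is a 2.5-fold lower number from compound 1 to compound 2 (0.40 log units; beyond the scatter); it shows that exchanging the group on an aromatic carbon of this ring moves the number beyond the scatter, but it does not show what dimethylamino does in that place, so it gives only a loose guide. For compound 3 the expected step is a 1.4-fold lower number from compound 2 to compound 3 (0.15 log units; within the scatter), a modest lowering at most, and possibly none beyond the scatter. Compound 3 is therefore estimated at 35000 nM, with a range from 9000 nM to 130000 nM, the width reflecting how little the two measured compounds settle the question.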

Compound 3, half-maximal inhibitory concentration: 11000 nM
Compound 3: the middle estimate sits 3.2-fold (0.50 log units) above what was measured; measured number inside the range.
By their numbers in this assay, from the lowest: compound 3; then compound 2; then compound 1.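

In this assay, dimethylamino on an aromatic carbon, para to a large group, gives a 4.5-fold lower number from compound 2 to compound 3 (0.65 log units; beyond the scatter). Among the compounds shown here, the earlier pair showed only that a number at this place rises with cyano relative to hydrogen; this step shows that replacing hydrogen can also lower it, beyond the scatter. Set against cyano, the same group gives an 11-fold lower number from compound 1 to compound 3 (1.05 log units; beyond the scatter), a large step, so the three compounds place hydrogen between cyano and dimethylamino, and the choice of group here covers a wider span than the first pair revealed. No measurement given here explains this order.

On these data alone, whether the lowering is particular to dimethylamino or would also come with a primary amine, a methoxy group or longer chains on the nitrogen remains open. So does whether dimethylamino would give a similar step at another carbon of that ring.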